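Swapping the Aryl Group on the Shared Core

A few compounds are considered here, and "the series" means these few. Any claim that something is new, unique, unknown or untested is made for them only; others in the source may bear on it.

Compound 1, `Clc1ccccc1-c1nnc(COc2ccc(-c3ccccc3)cc2)o1`, gives 59.1% in a functional assay on the whole organism (strain Wistar) for inhibition, with Rattus norvegicus as the target, read by paw edema, with a stated time of 3 h, at a dose of 10 mg/kg by the oral route; a lower number here means less inhibition, a higher number more inhibition at the dose given (going by the name of the read-out).
Compound 2, `CC(C)Cc1ccc(C(C)c2nnc(COc3ccc(-c4ccccc4)cc3)o2)cc1`, gives 77.3% in this assay.

Of the two measured compounds, compound 1 stands lowest in this assay, and its gap to compound 2 lies beyond the usual scatter of repeated measurements. Compound 3, `Fc1ccc(Nc2nnc(COc3ccc(-c4ccccc4)cc3)o2)cc1`, has not yet been measured. It differs from compound 1 in one place: (4-fluorophenyl)amino in place of 2-chlorophenyl on an aromatic carbon. The entering group carries one hydrogen-bond donor and one hydrogen-bond acceptor where the leaving group had none, and it sits on an aromatic carbon of the five-membered ring.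

Going by the values given here, no pair of measured compounds shows this exact change, so there is no measured step to lean on. A modest step in this assay is expected, with no direction that can be called beyond the scatter. Compound 3 is therefore estimated to give about 62%, within a range from 45% to 78%. That estimate corresponds to an expected step of a number 2.9 percentage points higher from compound 1 to compound 3 (within the scatter).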

Compound 3, a percentage reported as inhibition, in the whole organism at one dose (the size of the read-out at that dose, not a potency): 52.3%
Estimate against measurement, compound 3: 9.7 percentage points above; low and high end bracket the measured number.
By their numbers in this assay, from the lowest: compounds 3 and 1 (each within the scatter of the next); then compound 2.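

In this assay, putting (4-fluorophenyl)amino in place of 2-chlorophenyl gives a number 6.8 percentage points lower from compound 1 to compound 3 (within the scatter) for this change on an aromatic carbon of the five-membered ring. This position of the shared core therefore takes a group carrying one hydrogen-bond donor and one hydrogen-bond acceptor, where the leaving group had none, with no difference that can be told apart from the usual scatter of repeated measurements. Nothing available here explains how either compound behaves in the whole animal.

As far as these compounds go, compound 3 differs from compound 1 in both the amino nitrogen and the halogen on the phenyl ring, so the share of each stays open. A (2-chlorophenyl)amino group or a directly attached 4-fluorophenyl group at this carbon would separate the two.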